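A few compounds are considered here, and "the series" means these few. Any claim that something is new, unique, unknown or untested is made for them only; others in the source may bear on it.

Measured compounds in a functional assay on DU-145 cells (Homo sapiens) for inhibition, read by MTT assay, with a stated time of 72 h; on this read-out higher numbers stand for weaker inhibition of growth and lower numbers for stronger inhibition of growth:
- compound 1, `N#C/C(=C\c1ccc([N+](=O)[O-])cc1)C(=O)c1c[nH]c2ccccc12`: 59000 nM
- compound 2, `COc1ccc(CNC(=O)/C(C#N)=C/c2ccc[nH]2)cc1`: > 50000 nM, a limit of the assay
- compound 3, `N#C/C(=C\c1ccc[nH]1)C(=O)NCc1ccc(Cl)c(Cl)c1`: > 50000 nM, a limit of the assay

Compound 2 stands at no number of its own: in this assay compound 2 gives only the limit > 50000 nM. Compound 3 likewise gives only the limit > 50000 nM in this assay. Both sit at the limit of > 50000 nM in this assay, at which 2 of the 3 values shown sit. Within the data shown here, compound 1 is the single member with a number, and in this assay compound 1 gives 59000 nM. No two of these compounds differ in one place, so no measured step exists in the series.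

Compound 4, `COc1ccc(CNC(=O)/C(C#N)=C/c2ccoc2)cc1`, is the next member. The change from compound 2 is furan-3-yl in place of 1H-pyrrol-2-yl on a double-bonded chain carbon bound to a double-bonded chain carbon. With the starting point itself a limit, no direction can be set from the data, and the most probable outcome is again a limit rather than a number. The expected step is none beyond the scatter: a step that the limit leaves unreadable from compound 2 to compound 4. Compound 4 is expected to give 60000 nM in this assay, with a range from 20000 nM to 200000 nM.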

Compound 4, concentration for 50% growth inhibition: 7000 nM
Beside the measured number, compound 4's estimate is 8.6-fold (0.93 log units) above it; the measured number lies below the stated range.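

In this assay, furan-3-yl in place of 1H-pyrrol-2-yl on a double-bonded chain carbon bound to a double-bonded chain carbon gives an at least 7.1-fold lower number from compound 2 to compound 4 (0.85 log units; beyond the scatter). This position therefore affects growth inhibition, and compound 4 gives 7000 nM as a number of its own. The step has only a lower bound and its full size stays unknown because the starting point is a limit: the limit of > 50000 nM in this assay, at which 2 of the 4 values shown sit.

The change removes a hydrogen-bond donor, adds a hydrogen-bond acceptor, and alters the ring hetero atom and its point of attachment, and this single pair cannot separate these differences. Thiophen-3-yl or furan-2-yl at this place would help separate them, and whether furan-3-yl has a similar effect on the amide of compound 3 remains open.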